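A urea-to-amide swap on the biaryl edge

This account rests on a few compounds, and the source may have more. Where it says the series, first, only, none or still open, it means among the compounds named here.

Measured compounds:
compound 1, `CNC(=O)Nc1ccccc1-c1ccc(CN2C(=O)[C@H](NC(=O)CC(C)(C)N)CCc3ccccc32)cc1`, 50 nM
compound 2, `CCCNC(=O)NCc1ccccc1-c1ccc(CN2C(=O)[C@H](NC(=O)C(C)(C)N)CCc3ccccc32)cc1`, 144 nM
compound 3, `CC(C)(N)C(=O)N[C@@H]1CCc2ccccc2N(Cc2ccc(-c3ccccc3CNC(=O)NCc3ccccc3)cc2)C1=O`, 390 nM

In a functional assay (Pituitary gland cell) with Rattus norvegicus as the target (a lower number here means that less compound is needed, a higher number that more compound is needed for the effect), compound 1 gives the lowest of the three numbers, so it needs the least compound for the effect; compound 2 sits nearer to it and compound 3 furthest away, both beyond the scatter. Among the compounds with values here, the only single-point step among the measured compounds is a 2.7-fold higher number from compound 2 to compound 3 (0.43 log units; beyond the scatter), a modest change that touches the outer end of the urea chain, not the part of the molecule altered here.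

Compound 4, `CC(C)(N)CC(=O)N[C@@H]1CCc2ccccc2N(Cc2ccc(-c3ccccc3C(N)=O)cc2)C1=O`, differs from compound 1 in one place: carbamoyl in place of (methylcarbamoyl)amino on an aromatic carbon. Within the data shown here, no measured step bears directly on this change, since the measured pair varies the tail of the urea rather than replacing the urea itself. The expectation must therefore be cautious: the shared core and the amine-bearing amide side chain of compound 1 are kept, while a shorter group with one donor fewer takes the place of the urea. A modest move to a higher number seems most likely, though a step within the scatter cannot be ruled out. Compound 4 is expected to give 120 nM, between 40 nM and 400 nM, meaning an estimated step of a 2.4-fold higher number from compound 1 to compound 4 (0.38 log units; beyond the scatter).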

Compound 4, concentration for half-maximal effect: 80 nM
Beside the measured number, compound 4's estimate is 1.5-fold (0.18 log units) above it; measured number inside the range.
By their numbers in this assay, from the lowest: compounds 1, 4 and 2 (each within the scatter of the next, the first and the last beyond it); then compound 3.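

In this assay, putting carbamoyl in place of (methylcarbamoyl)amino on this aromatic carbon gives a 1.6-fold higher number from compound 1 to compound 4 (0.20 log units; within the scatter), so the two compounds cannot be told apart in this assay. The earlier step changed only the outer end of a urea chain, whereas this pair shows that the urea on this carbon can give way to a group with fewer heavy atoms and fewer hydrogen-bond donors without a change beyond the usual scatter, so, for this pair, the full urea is not needed to keep the number in this range. Why the number holds cannot be told from these data, as no measurement here addresses the cause.

Going by these compounds, this is a single pair on one side chain, so it remains open whether the same swap would behave alike in compounds carrying the amine-bearing amide side chain of compound 2. On these data alone, how other groups on this aromatic carbon would behave, such as a carboxylic acid, a nitrile or a simple amine, also remains open, as does the effect of removing the substituent altogether.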